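The source may report more compounds than this note shows. Statements on the series, on what has been measured and on what is new or still open speak of the compounds shown alone.

Measured so far in an assay on isolated protein for binding affinity to Gonadotropin-releasing hormone receptor (Homo sapiens); on this read-out lower numbers stand for stronger inhibition and higher numbers for weaker inhibition:
compound 1 `COc1cccc(-c2c(C)n(Cc3ccccc3F)c3nc(C(C)(C)C)c(CN(C)C)n3c2=O)c1`: 1700 nM
compound 2 `COc1cccc(-c2c(C)n(Cc3ccccc3F)c3nc(C(C)(C)C)c(CNCc4ccccc4)n3c2=O)c1`: 240 nM

Among the compounds with values here, compound 2 holds the lower of the two numbers; the only step in the set, a 7.1-fold lower number from compound 1 to compound 2 (0.85 log units; beyond the scatter), shows the benzylamino arm outscoring the dimethylamino one.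

Compound 3 `COc1cccc(-c2c(C)n(Cc3ccccc3F)c3nc(C(C)(C)C)c(CNCC4CCCCC4)n3c2=O)c1` carries cyclohexyl in place of phenyl on a saturated chain carbon bound to an amine nitrogen. Within the data shown here, no measured step touches this change; the one known step concerns a different part of the arm and offers no direct guide, so a step near the scatter is expected, a 1.7-fold higher number from compound 2 to compound 3 (0.22 log units; within the scatter), leaning weaker. Compound 3 is expected at 400 nM, range 120 nM to 1300 nM.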

Compound 3, inhibition constant: 430 nM
For compound 3 the middle estimate is 1.1-fold (0.03 log units) below the measured one; measured number inside the range.
By their numbers in this assay, from the lowest: compounds 2 and 3 (each within the scatter of the next); then compound 1.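

In this assay, cyclohexyl in place of phenyl on a saturated chain carbon bound to an amine nitrogen gives a 1.8-fold higher number from compound 2 to compound 3 (0.25 log units; within the scatter), so an aromatic ring is not needed at this place to stay within the scatter of compound 2. The advantage over the dimethylamino arm also holds without aromaticity, with a 4.0-fold lower number from compound 1 to compound 3 (0.60 log units; beyond the scatter). No evidence accounts for either step.

On these data alone, whether the advantage needs a ring at all remains open, as does the effect of a hetero atom in it. A straight hexyl chain or a pyridyl ring on the same amine would address both.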